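Sulfonamide substituent on the shared core: loss of the ring

This account rests on a few compounds, and the source may have more. Where it says the series, first, only, none or still open, it means among the compounds named here.

Three compounds share one core and differ only on the sulfonyl sulfur. Compound 1 `CNS(=O)(=O)c1ccc(NC(=O)NCc2ccncc2)cc1` carries methylamino there; in an assay on isolated protein for activation of Nicotinamide phosphoribosyltransferase (Homo sapiens) (on this read-out lower numbers stand for an effect already at smaller amounts and higher numbers for an effect only at larger amounts of compound), compound 1 gives 3230 nM. Compound 2 `O=C(NCc1ccncc1)Nc1ccc(S(=O)(=O)NCc2ccccc2)cc1` carries benzylamino and in this assay compound 2 gives 102 nM. Compound 3 `O=C(NCc1ccncc1)Nc1ccc(S(=O)(=O)N2CCc3ccccc3C2)cc1` carries 1,2,3,4-tetrahydroisoquinolin-2-yl, and in this assay compound 3 gives 142 nM. Compound 3 thus holds the second highest of the three numbers, close to compound 2 and far from compound 1.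

Compound 4 `CCN(CC)S(=O)(=O)c1ccc(NC(=O)NCc2ccncc2)cc1` is not yet measured. The change from compound 3 is diethylamino in place of 1,2,3,4-tetrahydroisoquinolin-2-yl on a sulfonyl sulfur. Among the measured compounds shown here, the steps that bear on it are a 32-fold lower number from compound 1 to compound 2 (1.50 log units; beyond the scatter) and a 23-fold lower number from compound 1 to compound 3 (1.36 log units; beyond the scatter), both large, each adding a carbon-only aromatic ring to the group on the sulfonyl sulfur; the step of a 1.4-fold higher number from compound 2 to compound 3 (0.14 log units; within the scatter) shows that the two ring-bearing groups sit together. Compound 4 goes the other way: the aromatic ring leaves and an acyclic diethylamino enters, which resembles the methylamino of compound 1 more than the groups of compound 2 or compound 3. A large rise is therefore expected in this assay, though the two extra carbons leave room for compound 4 to fall short of compound 1.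

The estimate for compound 4 is 1500 nM (range 500 nM to 5000 nM), meaning an expected step of an 11-fold higher number from compound 3 to compound 4 (1.02 log units; beyond the scatter).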

Compound 4, half-maximal effective concentration: 384 nM
Compound 4: middle estimate off by 3.9-fold (0.59 log units), on the high side; measured number outside the range, below it.
By their numbers in this assay, from the lowest: compounds 2 and 3 (each within the scatter of the next); then compound 4; then compound 1.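

In this assay, among the compounds shown here, the earlier compounds tied the low numbers to groups carrying a carbon-only aromatic ring, but compound 4 separates the two: with diethylamino on the sulfonyl sulfur and no ring at all, there is already an 8.4-fold lower number from compound 1 to compound 4 (0.92 log units; beyond the scatter). The aromatic ring is therefore not needed for a clear improvement on methylamino at this position, although the ring-bearing groups keep a modest, real advantage, with a 2.7-fold higher number from compound 3 to compound 4 (0.43 log units; beyond the scatter) and a 3.8-fold higher number from compound 2 to compound 4 (0.58 log units; beyond the scatter). No measurement shown explains why diethylamino falls where it does in this order.

The compounds shown leave open whether the gain over methylamino comes from the second chain on the sulfonamide nitrogen or from the added carbons, a question that dimethylamino and N-ethyl-N-methylamino would address. They also leave open whether a saturated ring such as piperidin-1-yl, or longer chains as in dipropylamino, would close the remaining gap to compound 3 without any aromatic ring.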